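The source may report more compounds than this note shows. Statements on the series, on what has been measured and on what is new or still open speak of the compounds shown alone.

Measured so far:
- compound 1, `CC1(C)SC(c2ccccc2N)=NN1C(=O)c1ccccc1`: 39.8%
- compound 2, `CC1(C)SC(c2cc(Cl)ccc2N)=NN1C(=O)C1CCCC1`: 21.3%
- compound 3, `CCC(=O)N1N=C(c2ccccc2N)SC1(C)C`: 19.2%

In an assay on isolated protein for inhibition of Nitric oxide synthase, inducible (Homo sapiens), read by scintillation counting, with a stated time of 30 min, tested at 50 uM (a higher number here means more inhibition at the concentration tested (going by the name of the read-out), a lower number less inhibition), compound 3 stands lowest of the three numbers. Compound 2 gives 21.3%, within the scatter of compound 3. Compound 1 gives 39.8%, beyond the scatter above compound 3, the gap being a number 20.6 percentage points lower from compound 1 to compound 3 (beyond the scatter).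

Compound 4, `CC1(C)SC(c2ccccc2N)=NN1C(=O)C1CCCC1`, is not yet measured; it differs from compound 3 by cyclopentyl in place of ethyl on a carbonyl carbon. Among the compounds with values here, no measured step makes exactly this change. Within the data shown here, the one single-place step known, a number 20.6 percentage points lower from compound 1 to compound 3 (beyond the scatter), concerns phenyl against ethyl on the same carbonyl carbon and is only a rough guide. Compound 2 carries the cyclopentyl but differs from compound 3 in a second place too, so its value shows only that the cyclopentyl series can sit near compound 3. A step of a number 5.8 percentage points higher from compound 3 to compound 4 (within the scatter) is expected, small and upward. Compound 4 is estimated at 25%, range 12% to 40%.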

Compound 4, a percentage reported as inhibition, at one concentration (the size of the read-out at that concentration, not a potency): 42.2%
Beside the measured number, compound 4's estimate is 17.2 percentage points below it, and the stated range ends below it.
By their numbers in this assay, from the lowest: compounds 3 and 2 (each within the scatter of the next); then compounds 1 and 4 (each within the scatter of the next).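

In this assay cyclopentyl in place of ethyl on a carbonyl carbon gives a number 23 percentage points higher from compound 3 to compound 4 (beyond the scatter) and so shows that a non-aromatic ring at this position can match phenyl, as cyclopentyl in place of phenyl gives a number 2.4 percentage points higher from compound 1 to compound 4 (within the scatter) here. With cyclopentyl held, hydrogen in place of chloro on an aromatic carbon gives a number 20.9 percentage points higher from compound 2 to compound 4 (beyond the scatter) and so ties the low number of compound 2 to the chloro, not to the cyclopentyl. No evidence at hand explains these steps.

Open, going by these compounds, is whether a longer chain such as butanoyl or a smaller ring such as cyclopropyl on this carbonyl carbon stays with compound 4 or falls towards compound 3. Also open, on these data alone, is whether fluoro or methoxy in place of that chloro carries the same step.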